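The source may hold more compounds than are shown below. What is called first, only, known or untested is meant among the compounds shown, and "the series" means these compounds.

Compound 1 `CCCc1ccc(NC2=CC(=O)c3nc4n(c3C2=O)[C@H]2OC[C@@H](O)[C@H]2OC4)cc1`: 4990 nM in a functional assay on HeLa cells (Homo sapiens) for inhibition, read by sulforhodamine B assay; on this read-out lower numbers stand for stronger inhibition and higher numbers for weaker inhibition. Compound 2 `O=C1C=C(N2CCC2)C(=O)c2c1nc1n2[C@H]2OC[C@@H](O)[C@H]2OC1`: in this assay compound 2 reports only a limit, > 16000 nM. Compound 3 `O=C1C(NC2CCCC2)=CC(=O)c2c1nc1n2[C@H]2OC[C@@H](O)[C@H]2OC1`: in this assay compound 3 likewise reports only a limit, > 16000 nM.

Compound 3 therefore stands at the limit of > 16000 nM in this assay, at which 2 of the 3 values shown sit; its number is not known, only that it lies beyond the reach of the measurement. Going by the values given here, the only compound with a real number is compound 1, and no step between measured compounds is available to say how any single change shifts the read-out.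

Compound 4 `O=C1C(N2CCC2)=CC(=O)c2c1nc1n2[C@H]2OC[C@@H](O)[C@H]2OC1` differs from compound 3 in one place: azetidin-1-yl in place of cyclopentylamino on a double-bonded ring carbon. Among the compounds with values here, compound 2 also carries azetidin-1-yl on its core and sits at the same limit, so there is nothing among the measured compounds pointing toward a gain. The step from compound 3 to compound 4 is expected to be none beyond the scatter, a step that the limit leaves unreadable from compound 3 to compound 4, with a fair chance that this assay again returns only a limit. Compound 4 is estimated at 20000 nM, within 6000 nM to 60000 nM.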

Compound 4, half-maximal inhibitory concentration: > 16000 nM
Compound 4: a limit, no number; the forecaster's own chance of this, stated with the estimate: 70%; the middle value is on the limit's open side.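

In this assay compound 4 returns only a limit (> 16000 nM). Going by these compounds alone, compound 3 also stands at a limit, so no step between compound 3 and compound 4 can be read. The compounds shown leave open whether azetidin-1-yl and cyclopentylamino differ at all in this position.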